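Extending the benzyl arm: from compound 2 to compound 3

The source may hold more compounds than are shown below. What is called first, only, known or untested is meant among the compounds shown, and "the series" means these compounds.

Measured compounds:
compound 1 `CCC(CC)(c1ccc(OCC(=O)C(C)(C)Cc2ccccc2)c(C)c1)c1ccc(OC[C@@H](O)CO)c(C)c1`: 21000 nM
compound 2 `CCC(CC)(c1ccc(OCC(O)C(C)(C)Cc2ccccc2)c(C)c1)c1ccc(OC[C@@H](O)CO)c(C)c1`: 11000 nM

In an assay on HL-60 cells for activation of vitamin D3 receptor (Homo sapiens) (on this read-out higher numbers stand for an effect only at larger amounts of compound and lower numbers for an effect already at smaller amounts), compound 2 gives 11000 nM, the lowest of the two numbers shown, while compound 1 gives 21000 nM. Within the data shown here, the single measured step, a 1.9-fold lower number from compound 1 to compound 2 (0.28 log units; within the scatter), falls within the scatter, so the two compounds cannot be ordered against each other. Compound 3 `CCC(CC)(c1ccc(OCC(O)C(C)(C)CCc2ccccc2)c(C)c1)c1ccc(OC[C@@H](O)CO)c(C)c1` differs from compound 2 by benzyl in place of phenyl on a saturated chain carbon, three bonds along the chain from an oxygen on a saturated carbon. Among the measured compounds shown here, no measured step touches this place: the step from compound 1 to compound 2 alters the group bound to the oxygen on the aromatic ring, not the chain carbon addressed here, and the set holds no step beyond the scatter at all. Compound 3 is therefore expected to remain close to compound 2, with no change at the digits printed from compound 2 to compound 3 (within the scatter) as the estimated step. The estimate for compound 3 is 11000 nM, with a range from 4000 nM to 30000 nM.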

Compound 3, half-maximal effective concentration: 7100 nM
Estimate against measurement, compound 3: 1.5-fold (0.19 log units) above; the measured number falls inside the stated range.
By their numbers in this assay, from the lowest: compounds 3, 2 and 1 (each within the scatter of the next, the first and the last beyond it).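

In this assay, among these compounds, the exchange of phenyl for benzyl at this saturated chain carbon reads a 1.5-fold lower number from compound 2 to compound 3 (0.19 log units; within the scatter) and gives the first measured step at this place. It shows that the arm can run as 1,1-dimethyl-3-phenylpropyl instead of 1-benzyl-1-methylethyl without a step beyond the scatter, so benzyl and phenyl cannot be ordered against each other here. No measurement offered with these compounds accounts for this result.

From the compounds shown here alone, whether a longer chain ending in phenyl would give a step beyond the scatter remains open. So does the outcome of placing an amine or a carboxylic acid on this saturated chain carbon in place of benzyl, since every arm shown here ends in an unsubstituted phenyl ring.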